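Taking the bromo group off compound 3

A few compounds are considered here, and "the series" means these few. Any claim that something is new, unique, unknown or untested is made for them only; others in the source may bear on it.

Of the compounds shown here, three sharing one core have so far been measured in a functional assay on HeLa cells (Homo sapiens) for antiproliferative activity, read by sulforhodamine B assay, with a stated time of 48 h (on this read-out higher numbers stand for weaker inhibition and lower numbers for stronger inhibition), on the same footing. Compound 1 (`COc1cc(C(=O)/C=C\Nc2ccc(-c3nc4cc(OC)c(OC)c(OC)c4s3)cc2C)cc([N+](=O)[O-])c1OC`) gives 13100 nM in this test, compound 2 (`COc1ccc(C(=O)/C=C\Nc2ccc(-c3nc4cc(OC)c(OC)c(OC)c4s3)cc2C)cc1[N+](=O)[O-]`) gives 13400 nM and compound 3 (`COc1cc(C(=O)/C=C\Nc2ccc(-c3nc4cc(OC)c(OC)c(OC)c4s3)cc2C)c(Br)c(OC)c1OC`) gives 14300 nM alongside them. Compound 3 therefore stands within the scatter of both other compounds, and the three cannot be put in order.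

The next compound, compound 4 (`COc1cc(C(=O)/C=C\Nc2ccc(-c3nc4cc(OC)c(OC)c(OC)c4s3)cc2C)cc(OC)c1OC`), differs from compound 3 by hydrogen in place of bromo on an aromatic carbon. For the measured compounds named here, no measured step removes a bromo group. The nearest in kind is hydrogen in place of methoxy on an aromatic carbon, a 1.0-fold higher number from compound 1 to compound 2 (0.01 log units; within the scatter) and this lies within the scatter. Going by the values given here, no measured compound lacks both a nitro and a bromo group, so the data leave room for a larger move, mainly towards lower numbers. In this assay no shift beyond the scatter is therefore expected, only a slight lean towards a lower number. The estimated step is a 1.4-fold lower number from compound 3 to compound 4 (0.16 log units; within the scatter) under this expectation. Compound 4 is expected at 10000 nM with an estimated range from 2500 nM to 20000 nM in this assessment.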

Compound 4, half-maximal inhibitory concentration: 11100 nM
Compound 4: middle estimate off by 1.1-fold (0.05 log units), on the low side; low and high end bracket the measured number.
By their numbers in this assay, from the lowest: compounds 4, 1, 2 and 3 (each within the scatter of the next).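

Hydrogen in place of bromo on this aromatic carbon, ortho to a large group and ortho to a methoxy group, gives a 1.3-fold lower number from compound 3 to compound 4 (0.11 log units; within the scatter) in this assay, so the first direct reading at this position shows no separation between bromo and hydrogen. The two steps that replace the nitro-bearing aryl pattern agree with this: methoxy in place of nitro on an aromatic carbon gives a 1.2-fold lower number from compound 1 to compound 4 (0.07 log units; within the scatter), and 3,4,5-trimethoxyphenyl in place of 4-methoxy-3-nitrophenyl on a carbonyl carbon gives a 1.2-fold lower number from compound 2 to compound 4 (0.08 log units; within the scatter), so compound 4, which carries neither a nitro nor a bromo group, stays level with the three earlier compounds. Nothing available speaks to why these changes leave the number in place.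

The compounds shown vary this ring only among hydrogen, bromo, nitro and methoxy, so it remains open whether an amine, a hydroxyl or a carboxylic acid on the same aromatic carbon would move the number beyond the scatter. Going by these compounds, it also remains open whether this flat picture would hold with a different group in place of the methyl on the aniline ring of the shared core.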